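The compounds below may be only part of what the source reports. "The series", "measured", "known", "first", "only" and "open" are said of these compounds alone.

Within the data shown here, compound 2 `O=C1[C@@H](NS(=O)(=O)c2cc3cccnc3s2)CCN1Cc1cc2c[nH]ccc-2n1` stands at the lower of the two numbers measured so far in an assay on isolated protein for inhibition of coagulation factor X (Oryctolagus cuniculus), tested at 1 uM (on this read-out lower numbers stand for less inhibition and higher numbers for more inhibition at the one concentration tested (going by the name of the read-out)), where compound 2 gives 18%. Among the measured compounds shown here, its only neighbour, compound 1 `O=C1[C@@H](NS(=O)(=O)c2cc3c(Cl)nccc3s2)CCN1Cc1cc2c[nH]ccc-2n1`, gives 35% in this assay, and the one step between them, a number 17 percentage points lower from compound 1 to compound 2 (beyond the scatter), shows that taking a chlorine off the group on the sulfonyl sulfur cost a modest but real amount of inhibition.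

Compound 3 `O=C1[C@@H](NS(=O)(=O)c2nc3cc(Cl)ccc3[nH]2)CCN1Cc1cc2c[nH]ccc-2n1` carries a different group on that same sulfonyl sulfur: a group of 10 heavy atoms (7 carbon, 2 nitrogen, 1 chlorine; one five-membered aromatic ring with 2 hetero atoms, one six-membered aromatic ring of carbon only) in place of a group of 9 heavy atoms (7 carbon, 1 nitrogen, 1 sulfur; one five-membered aromatic ring with 1 hetero atom, one six-membered aromatic ring with 1 hetero atom), on a sulfonyl sulfur. For the measured compounds named here, the change brings in a 5-chloro-1H-benzimidazol-2-yl group with one hydrogen-bond donor, a kind of change on which no measured step speaks directly. The step from compound 1 to compound 2 shows only that the presence of a chlorine on the ring system mattered; it does not tell how an exchange of the whole ring system would fare.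

With that single, indirect precedent, compound 3 is expected to give about 25% in this assay, within a wide range of 3% to 60%, meaning an estimated step of a number 7 percentage points higher from compound 2 to compound 3 (within the scatter).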

Compound 3, a percentage reported as inhibition, at one concentration (the size of the read-out at that concentration, not a potency): 31%
Beside the measured number, compound 3's estimate is 6 percentage points below it; the measured number falls inside the stated range.
By their numbers in this assay, from the lowest: compound 2; then compounds 3 and 1 (each within the scatter of the next).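

The result shows that the sulfonyl sulfur accepts a change of the whole ring system, not only the loss of a chlorine: in this assay, 5-chloro-1H-benzimidazol-2-yl in place of the chlorine-free group gives a number 13 percentage points higher from compound 2 to compound 3 (beyond the scatter). Against the chlorine-bearing group of compound 1, the same entering group gives a number 4 percentage points lower from compound 1 to compound 3 (within the scatter), so two groups with different ring systems, each carrying a chlorine, cannot be told apart on this read-out, while compound 2, the one compound without a chlorine, stands apart from both. Nothing measured here explains these differences.

The compounds shown leave open whether the chlorine or the benzimidazole ring accounts for the step from compound 2, since that step changes both at once; the unsubstituted 1H-benzimidazol-2-yl group would separate the two, and bromine or a methyl group in the chlorine's place would show whether chlorine itself matters. They also leave open how these small differences at a single concentration would translate into potency, and whether an amine or a carboxylic acid on the ring system would be accepted on the sulfonyl sulfur.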